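The compounds below may be only part of what the source reports. "The series", "measured", "known", "first", "only" and "open" are said of these compounds alone.

Measured in a functional assay on A549 cells (Homo sapiens) for inhibition, read by sulforhodamine B assay, with a stated time of 72 h; on this read-out lower numbers stand for stronger inhibition and higher numbers for weaker inhibition:
- compound 1 `Nc1sc(-c2ccc(Cl)cc2)c(-c2ccc(Cl)cc2)c1C(=O)NC1CCC(O)CC1`: 250 nM
- compound 2 `Nc1sc(-c2ccc(Cl)cc2)c(-c2ccc(Cl)cc2)c1C(=O)NCc1ccccc1`: 16300 nM
- compound 3 `CS(=O)(=O)Nc1sc(-c2ccc(Cl)cc2)c(-c2ccc(Cl)cc2)c1C(=O)NC1CC1`: "not determined" (no result reported)

Among the compounds with values here, compound 3 has no number to stand on, since for compound 3 the entry is "not determined" (no result reported), and so no step can start from it. Compound 4 `Nc1sc(-c2ccc(Cl)cc2)c(-c2ccc(Cl)cc2)c1C(=O)NC1CC1` is compound 3 with hydrogen in place of methylsulfonyl on a nitrogen on an aromatic ring, methanesulfonamido to amino: hydrogen in place of methylsulfonyl on a nitrogen on an aromatic ring. Compound 4 thus shares the amino group of compound 1 and compound 2, while keeping the amide substituent of compound 3.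

Within the data shown here, the only measured step, a 65-fold higher number from compound 1 to compound 2 (1.81 log units; beyond the scatter), concerns the amide-type nitrogen rather than this one. It bears on the change only indirectly, showing that a swap at that amide nitrogen can move the number by a large amount. No size or direction of step can be expected from compound 3 in this assay. The expectation instead rests on the span from compound 1 at 250 nM to compound 2 at 16300 nM. For compound 4 the expected value is 2500 nM, with an estimated range from 300 nM to 20000 nM.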

Compound 4, half-maximal inhibitory concentration: 1950 nM
For compound 4 the middle estimate is 1.3-fold (0.11 log units) above the measured one, within the range that was stated.
By their numbers in this assay, from the lowest: compound 1; then compound 4; then compound 2.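

Cyclopropyl on the amide-type nitrogen places compound 4 between the other two amino compounds in this assay: replacing benzyl gives an 8.4-fold lower number from compound 2 to compound 4 (0.92 log units; beyond the scatter), and replacing 4-hydroxycyclohexyl gives a 7.8-fold higher number from compound 1 to compound 4 (0.89 log units; beyond the scatter). Among these three compounds, which share the amino group, compound 1 therefore gives the lowest number and compound 2 the highest, so the amide substituent alone separates all three. The step from methanesulfonamido to amino cannot be read, as compound 3 has no result, and nothing available accounts for the differences at the amide-type nitrogen.

From the compounds shown here alone, what methylsulfonyl does on the nitrogen on an aromatic ring remains open, as does the effect of an acetyl group there. Going by these compounds, it also remains open how a plain cyclohexyl group on the amide-type nitrogen would compare with the 4-hydroxycyclohexyl group of compound 1.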